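A few compounds are considered here, and "the series" means these few. Any claim that something is new, unique, unknown or untested is made for them only; others in the source may bear on it.

In a functional assay on A549 cells (Homo sapiens) for antiproliferative activity, read by MTT assay, with a stated time of 48 h (a lower number here means a stronger inhibitor, a higher number a weaker inhibitor), compound 1 `COc1ccc(-c2cc3c(cn2)[nH]c(=O)n3-c2cc(OC)c(OC)c(OC)c2)cc1F` gives 2020 nM while compound 2 `CCOc1ccc(-c2cc3c(cn2)[nH]c(=O)n3-c2cc(OC)c(OC)c(OC)c2)cc1` gives 5300 nM and compound 3 `CCOc1ccc(-c2cc3c(cn2)[nH]c(=O)n3-c2cc(OC)c(OC)c(OC)c2)cc1F` gives 2540 nM on the same scale. Compound 3 cannot be told apart from compound 1 here, and compound 2 has the highest number of the three. Compound 4 `COc1ccc(-c2cc3c(cn2)[nH]c(=O)n3-c2cc(OC)c(OC)c(OC)c2)cc1C(=O)O` carries 3-carboxy-4-methoxyphenyl in place of 4-ethoxy-3-fluorophenyl on an aromatic carbon on the shared core. Moving between methoxy and ethoxy made little difference, with a 1.3-fold higher number from compound 1 to compound 3 (0.10 log units; within the scatter) in the data. Fluoro in place of hydrogen counted for more, with a 2.1-fold lower number from compound 2 to compound 3 (0.32 log units; beyond the scatter) in the data, and compound 4 has no fluoro. For the measured compounds named here, no tested compound carries a carboxy group, so that part of the change has no guide. A modest weakening is therefore expected, with a 2.4-fold higher number from compound 3 to compound 4 (0.37 log units; beyond the scatter) as the estimated step. For compound 4 the estimate is 6000 nM with an expected range from 2000 nM to 20000 nM allowing for that unknown.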

Compound 4, half-maximal inhibitory concentration: 1280 nM
Beside the measured number, compound 4's estimate is 4.7-fold (0.67 log units) above it; measured number below the stated range.
By their numbers in this assay, from the lowest: compounds 4, 1 and 3 (each within the scatter of the next); then compound 2.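

In this assay, this position accepts a carboxy group without loss: putting it where fluoro stood gives a 1.6-fold lower number from compound 1 to compound 4 (0.20 log units; within the scatter), and replacing the whole 4-ethoxy-3-fluorophenyl gives a 2.0-fold lower number from compound 3 to compound 4 (0.30 log units; within the scatter). For the compounds shown here, measured against the fluorine-free 4-ethoxyphenyl, the new group gives a 4.1-fold lower number from compound 2 to compound 4 (0.62 log units; beyond the scatter), so fluoro is not the only group on this ring that goes with a lower number than compound 2 shows. Nothing available here explains why the carboxy group fits this pattern. Going by these compounds, whether a methyl ester or an amine in place of the carboxy group would give a similar number remains open.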